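The source may report more compounds than this note shows. Statements on the series, on what has been measured and on what is new or still open speak of the compounds shown alone.

Compound 1 `CCOC(=O)c1cccc(-c2ccc(N(C)C)cc2)c1` gives 40000 nM in an assay on COS-7 cells for inhibition of patatin-like phospholipase domain-containing protein 2 (Mus musculus); a higher number here means a weaker inhibitor, a lower number a stronger inhibitor.
Compound 2 `CCOc1ccc(-c2cccc(NC(=O)N(C)C)c2)cc1` gives 70000 nM.
Compound 3 `CN(C)C(=O)Nc1cccc(-c2ccc(N(C)C)cc2)c1` reaches only the limit < 5000 nM, which is a boundary of the measurement and not a number.

On these data alone, compound 3 is therefore the strongest of the three only in the sense that its value lies beyond the limit (the limit of < 5000 nM in this assay, at which 1 of the 3 values shown sits); how far it lies there is unknown. Two steps lead to it: an at least 8.0-fold lower number from compound 1 to compound 3 (0.90 log units; beyond the scatter) and an at least 14-fold lower number from compound 2 to compound 3 (1.14 log units; beyond the scatter). The step to compound 4 `CC(C)COC(=O)Nc1cccc(-c2ccc(N(C)C)cc2)c1` is a different one, (isobutoxy in place of dimethylamino on a carbonyl carbon), turning the urea of compound 3 into a carbamate. Among the measured compounds shown here, no measured pair changes this carbonyl substituent alone, so neither step bears on it directly. The nearest comparison is compound 1, whose ester gives 40000 nM, a weak result next to the urea of compound 3. A carbamate sits between those two, so a weaker result than compound 3 is expected, though of uncertain size. The step of an at least 2.0-fold higher number from compound 3 to compound 4 (0.30 log units; that floor lies within the scatter) is an estimate in this assay. Compound 4 is expected to give 10000 nM, within 2000 nM to 50000 nM.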

Compound 4, half-maximal inhibitory concentration: 22000 nM
Compound 4: middle estimate off by 2.2-fold (0.34 log units), on the low side; low and high end bracket the measured number.
By their numbers in this assay, from the lowest: compounds 4, 1 and 2 (each within the scatter of the next, the first and the last beyond it). At a limit, below all of these: compound 3.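

In this assay, among the compounds shown here, putting isobutoxy in place of dimethylamino on the carbonyl carbon gives an at least 4.4-fold higher number from compound 3 to compound 4 (0.64 log units; beyond the scatter), and this is the first step here that alters this carbonyl substituent alone, with the amide-type nitrogen and the rest of the core kept. Keeping that nitrogen on the carbonyl is therefore not enough on its own to hold the result, and the other group on this carbon also counts. On these data alone, compound 3 stands at a limit and not at a number, so this step is only a floor and its full size is unknown: the limit of < 5000 nM in this assay, at which 1 of the 4 values shown sits.

The change swaps a nitrogen for an oxygen and alters the chain as well, and these compounds do not tell which of the two carries the step. A methoxy group or a diethylamino group on the same carbonyl carbon would pull those two apart.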